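The compounds below may be only part of what the source reports. "The series", "measured", "known", "first", "only" and "open" are said of these compounds alone.

Measured so far in a functional assay on DU-145 cells (Homo sapiens) for cytotoxicity, read by MTT assay, with a stated time of 48 h; on this read-out lower numbers stand for stronger inhibition and higher numbers for weaker inhibition
compound 1 `COc1ccc(-c2nc3ccccn3c2C(=O)/C=C\Nc2cc(OC)cc(OC)c2)cc1` at 6260 nM
compound 2 `COc1ccc(-c2nc3ccccn3c2C(=O)/C=C\Nc2cnc3ccccc3c2)cc1` at 5280 nM

Compound 2 stands level with compound 1 within the scatter (a 1.2-fold lower number from compound 1 to compound 2 (0.07 log units; within the scatter)). The next step leads to compound 3 (`O=C(/C=C\Nc1cnc2ccccc2c1)c1c(-c2ccccc2)nc2ccccn12`), with hydrogen in place of methoxy on an aromatic carbon, that is 4-methoxyphenyl to phenyl (hydrogen in place of methoxy on an aromatic carbon). Within the data shown here, the one measured step (a 1.2-fold lower number from compound 1 to compound 2 (0.07 log units; within the scatter)) changes a group on an amine nitrogen, not this aromatic carbon, so no measured step tests the methoxy. Nothing beyond the scatter is expected in this assay in either direction (a 1.1-fold higher number from compound 2 to compound 3 (0.06 log units; within the scatter)). For compound 3 the expected value is 6000 nM (estimated range 2500 nM to 14000 nM).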

Compound 3, half-maximal inhibitory concentration: 2440 nM
The estimate for compound 3 lay 2.5-fold (0.39 log units) above the measured number, and the stated range ends above it.
By their numbers in this assay, from the lowest: compound 3; then compounds 2 and 1 (each within the scatter of the next).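

In this assay, hydrogen in place of methoxy on the aromatic carbon (a 2.2-fold lower number from compound 2 to compound 3 (0.34 log units; beyond the scatter)) is the only step shown that lies beyond the scatter, and the phenyl compound carries the lower number. The step on the amine nitrogen (a 1.2-fold lower number from compound 1 to compound 2 (0.07 log units; within the scatter)) stayed within the scatter, so this aromatic carbon is the one place shown where a change moves the number. No evidence bears on the reason for this step. As far as these compounds go, whether fluoro, chloro, hydroxy or an amine at this carbon would give a lower or higher number stays open. Also open, from the compounds shown here alone, is whether the same step holds with 3,5-dimethoxyphenyl on the amine nitrogen.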